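Swapping methyl for chloro on the amino-phenyl arm

The compounds below may be only part of what the source reports. "The series", "measured", "known", "first", "only" and "open" are said of these compounds alone.

Of the compounds shown here, three sharing one core have been tested in a functional assay on the whole organism (strain Wister albino) for inhibition, with Rattus norvegicus as the target, read by paw edema, with stated times of 1 h and 3 h, at a dose of 50 mg/kg by the intraperitoneal route; a higher number here means more inhibition at the dose given (going by the name of the read-out), a lower number less inhibition. Compound 1 `CCOC(=O)c1c(-c2ccc(Cl)cc2)cc(-c2ccccc2)nc1N1CCN(C)CC1` gives 67.8%. Compound 2 `CCOC(=O)c1c(-c2ccc(Cl)cc2)cc(-c2ccccc2)nc1Nc1ccc(C)cc1` gives 82.4%, and the change a number 14.6 percentage points higher from compound 1 to compound 2 (beyond the scatter) arises from (4-methylphenyl)amino in place of 4-methylpiperazin-1-yl. Compound 3 `CCOC(=O)c1c(-c2ccc(Cl)c(Cl)c2)cc(-c2ccccc2)nc1Nc1ccc(C)cc1` gives 59.3%; here chloro in place of hydrogen on an aromatic carbon brings a number 23.1 percentage points lower from compound 2 to compound 3 (beyond the scatter). Compound 3 thus sits close to compound 1, within the scatter, and beneath compound 2, beyond the scatter.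

Compound 4 `CCOC(=O)c1c(-c2ccc(Cl)c(Cl)c2)cc(-c2ccccc2)nc1Nc1ccc(Cl)cc1` differs from compound 3 by chloro in place of methyl on an aromatic carbon. For the measured compounds named here, no measured step exchanges these two groups on this ring, so the closest guide is indirect: the step from compound 2 to compound 3 shows that adding chloro elsewhere lowered inhibition, while the step from compound 1 to compound 2 concerns a different group altogether. Neither tells how chloro behaves on the amino-phenyl ring. The expectation is therefore a step of a number 4.3 percentage points lower from compound 3 to compound 4 (within the scatter), small and not clearly beyond the scatter, leaning slightly downward. Compound 4 is estimated to give 55% in this assay, between 35% and 72%.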

Compound 4, a percentage reported as inhibition, in the whole organism at one dose (the size of the read-out at that dose, not a potency): 62.2%
Compound 4: middle estimate off by 7.2 percentage points, on the low side, within the range that was stated.
By their numbers in this assay, from the lowest: compounds 3, 4 and 1 (each within the scatter of the next); then compound 2.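

Compound 3 and compound 4 give the first direct view of the aromatic carbon para to a large group on the amino-phenyl arm, and in this assay exchanging methyl for chloro there gives a number 2.9 percentage points higher from compound 3 to compound 4 (within the scatter). The two compounds therefore cannot be told apart at this dose, so on this core, which carries the extra chloro of compound 3, the (4-methylphenyl)amino and (4-chlorophenyl)amino arms read alike, unlike the larger shifts seen at the other two places changed so far. No measurement shown here offers an explanation for why these two groups read alike.

From the compounds shown here alone, whether the same exchange would also leave the reading in place on the core of compound 2, where the step of a number 23.1 percentage points lower from compound 2 to compound 3 (beyond the scatter) shows that the extra chloro matters, remains open. Also open is how a methoxy group, an amine or a carboxylic acid would read on this same aromatic carbon, since methyl and chloro are the only two groups shown there.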